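Bromo for cyclopentyloxy at the weak end of the series

The source may hold more compounds than are shown below. What is called first, only, known or untested is meant among the compounds shown, and "the series" means these compounds.

In a functional assay on AGS cells (Homo sapiens) for antiproliferative activity, read by MTT assay, with a stated time of 48 h (on this read-out higher numbers stand for weaker inhibition of growth and lower numbers for stronger inhibition of growth), compound 2 `COc1ccccc1OCCNc1ccc(=O)n(Cc2ccc(OC)c(OC3CCCC3)c2)n1` gives > 100000 nM, which is a limit and not a number. Compound 1 `COc1ccccc1OCCNc1cnn(Cc2ccc(OC)c(OCC3CC3)c2)c(=O)c1Cl` gives > 100000 nM, also a limit. Compound 2 therefore sits with compound 1 at the limit of > 100000 nM in this assay, at which 2 of the 3 values shown sit. Compound 3 `COc1ccccc1OCCNc1ccc(=O)n(Cc2ccc(OC(F)F)c(OC3CCCC3)c2)n1` gives a number, 23600 nM.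

Among the compounds with values here, the only measured step is an at least 4.2-fold lower number from compound 2 to compound 3 (0.62 log units; beyond the scatter). It puts difluoromethyl in place of methyl on an oxygen on an aromatic ring, and the cyclopentyloxy stays.

Compound 4 `COc1ccc(Cn2nc(NCCOc3ccccc3OC)ccc2=O)cc1Br` carries a different change: bromo in place of cyclopentyloxy on an aromatic carbon. This is bromo in place of cyclopentyloxy on an aromatic carbon, ortho to a methoxy group. Within the data shown here, no measured step covers this swap, so the step above bears on it only indirectly, as a sign of how far one change has moved this assay.

The expected step is small and toward a lower number, and may not exceed the scatter: an at least 1.2-fold lower number from compound 2 to compound 4 (0.09 log units; that floor lies within the scatter). Compound 4 is estimated at 80000 nM, with an expected range of 25000 nM to 250000 nM.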

Compound 4, concentration for 50% growth inhibition: > 100000 nM
Compound 4: a limit, no number (the forecaster's own chance of this, stated with the estimate: 65%); at least 1.2-fold (0.09 log units) between middle value and limit.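

In this assay compound 4 gives > 100000 nM, a limit. Within the data shown here, compound 2 gives > 100000 nM, also a limit, so no step from compound 2 to compound 4 can be read. The compounds shown leave open whether bromo in place of cyclopentyloxy shifts growth inhibition at all.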